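The compounds below may be only part of what the source reports. "The series", "measured", "known", "first", "only" and "open" are said of these compounds alone.

The measured compounds and their values in a physicochemical assay for solubility, with a stated time of 18 h, at pH 7.4; a lower number here means a less soluble compound, a higher number a more soluble compound:
Compound 1 `COc1ccc(F)cc1CNCCCNc1ccnc2cc(Cc3cc(C)cc(C)c3)ccc12` gives 4200 nM.
Compound 2 `Cc1cc(C)cc(Cc2ccc3c(NCCCNCc4ccco4)ccnc3c2)c1` gives 4200 nM.
Compound 3 `COc1cccc(CNCCCNc2ccnc3cc(-c4cccc5ccccc45)ccc23)c1O` gives 32000 nM.

Compound 2 stands level with compound 1 at the digits shown, and the two together give the lowest numbers of the three; compound 3 gives a higher number, beyond the scatter. For the measured compounds named here, the only step between compounds that differ in one place runs from compound 1 to compound 2: no change at the digits printed from compound 1 to compound 2 (within the scatter). That step exchanges the group on the saturated chain carbon bound to an amine nitrogen and leaves the rest of the molecule untouched.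

Compound 4 `Clc1ccc(Oc2ccc3c(NCCCNCc4ccco4)ccnc3c2)cc1` differs from compound 2 at the other end of the core: 4-chlorophenoxy in place of 3,5-dimethylbenzyl on an aromatic carbon. No measured step alters the group on this aromatic carbon alone, so nothing shown tells how large a change in this assay to expect or in which direction. Compound 3 carries another group at that carbon but also differs from compound 2 in a second place, so its higher number cannot be tied to one change. The estimate for compound 4 therefore stays close to compound 2, with a step of a 1.4-fold higher number from compound 2 to compound 4 (0.15 log units; within the scatter) expected to lie within the scatter. The expected value for compound 4 is 6000 nM, with a range from 2000 nM to 18000 nM.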

Compound 4, solubility: 14500 nM
Compound 4: the middle estimate sits 2.4-fold (0.38 log units) below what was measured, and the stated range covers the measured number.
By their numbers in this assay, from the lowest: compounds 1 and 2 (each within the scatter of the next); then compound 4; then compound 3.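

In this assay, for the compounds shown here, the step of a 3.5-fold higher number from compound 2 to compound 4 (0.54 log units; beyond the scatter) shows that a single exchange on this aromatic carbon of the shared core can move the number beyond the scatter, whereas the only earlier single exchange, on the saturated chain carbon bound to an amine nitrogen, gave no change at the digits printed from compound 1 to compound 2 (within the scatter) and left the number unmoved. The 4-chlorophenoxy group brings an oxygen, a chlorine and a hydrogen-bond acceptor that 3,5-dimethylbenzyl lacks, while both groups hold one six-membered aromatic ring of carbon only, so these differences arrive together and this one step cannot separate them. Nothing measured here accounts for the higher number.

The compounds shown leave open whether the oxygen or the chlorine goes with the step, which plain phenoxy or 4-chlorobenzyl at this carbon would help to separate. They also leave open how a morpholine or a carboxylic acid at this carbon would compare.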